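The source may report more compounds than this note shows. Statements on the series, on what has been measured and on what is new or still open speak of the compounds shown alone.

Of the compounds shown here, three built on one shared core have been measured in an ADME assay on microsomes from liver (Homo sapiens) for metabolic stability, read by LC-MS, using NADPH, with stated times of 5 min and 30 min, tested at 1 uM; a lower number here means slower removal, a higher number faster removal of the compound. Compound 1 `Cc1nccn1-c1cnc(NCc2c(F)ccc3c2CCO3)c2cn[nH]c(=O)c12` gives 8 mL.min-1.g-1, and compound 2 `Cc1ncc(-c2cnc(NCc3c(F)ccc4c3CCO4)c3cn[nH]c(=O)c23)n1C` gives 10 mL.min-1.g-1. Compound 3 `CNC(=O)c1cc(-c2cnc(NCc3c(F)ccc4c3CCO4)c3cn[nH]c(=O)c23)n(C)n1` gives < 3 mL.min-1.g-1, which is a limit of the assay and not a number.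

Compound 4 `CN(c1ccn(C)n1)c1cnc(NCc2c(F)ccc3c2CCO3)c2cn[nH]c(=O)c12` has not yet been measured. In it, methyl(1-methyl-1H-pyrazol-3-yl)amino takes the place of 1-methyl-3-(methylcarbamoyl)-1H-pyrazol-5-yl on an aromatic carbon (methyl(1-methyl-1H-pyrazol-3-yl)amino in place of 1-methyl-3-(methylcarbamoyl)-1H-pyrazol-5-yl on an aromatic carbon).

For the measured compounds named here, two measured steps bear most directly on this change. Both bring in the group that compound 4 gives up: an at least 2.6-fold lower number from compound 1 to compound 3 (0.42 log units; beyond the scatter) and an at least 3.3-fold lower number from compound 2 to compound 3 (0.52 log units; beyond the scatter). A third step, between the two other groups, gives a smaller contrast: a 1.3-fold higher number from compound 1 to compound 2 (0.10 log units; within the scatter). Going by the values given here, no measured compound carries the group that enters compound 4, so these steps are only a loose guide.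

Read in reverse, the two larger steps point to a rise in this assay of similar size. The expected change is an at least 2.3-fold higher number from compound 3 to compound 4 (0.36 log units; beyond the scatter). Compound 4 is expected at an estimated 7 mL.min-1.g-1. Its estimated range runs from 3 mL.min-1.g-1 to 18 mL.min-1.g-1.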

Compound 4, intrinsic clearance in microsomes: 62 mL.min-1.g-1
Beside the measured number, compound 4's estimate is 8.9-fold (0.95 log units) below it; measured number above the stated range.
By their numbers in this assay, from the lowest: compounds 1 and 2 (each within the scatter of the next); then compound 4. At a limit, below all of these: compound 3.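

In this assay, for the compounds shown here, this position on the shared core proves able to carry much faster removal than the earlier compounds showed: methyl(1-methyl-1H-pyrazol-3-yl)amino in place of 1-methyl-3-(methylcarbamoyl)-1H-pyrazol-5-yl gives an at least 20-fold higher number from compound 3 to compound 4 (1.31 log units; beyond the scatter). Going by these compounds alone, the entering group also stands apart from the two other groups, with a 6.2-fold higher number from compound 2 to compound 4 (0.79 log units; beyond the scatter) and a 7.8-fold higher number from compound 1 to compound 4 (0.89 log units; beyond the scatter), whereas those two groups differ only within the scatter, so the earlier compounds gave no sign of a change this size from the imidazole groups. The value of compound 3 is a limit of the assay and not a number, so the first of these steps gives only a minimum size: the limit of < 3 mL.min-1.g-1 in this assay, at which 1 of the 4 values shown sits.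

The change from compound 3 to compound 4 alters several things at once, since the methylcarbamoyl is lost and the pyrazole ring is now joined through a methyl-bearing amino nitrogen, and the compounds shown cannot tell which of these goes with the faster removal. A plain amino link without that methyl, or an ether oxygen as the link, would be needed to separate these features.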